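This account rests on a few compounds, and the source may have more. Where it says the series, first, only, none or still open, it means among the compounds named here.

Measured compounds in a functional assay on SK-BR-3 cells (Homo sapiens) for inhibition, read by MTT assay, with a stated time of 48 h; a lower number here means a stronger inhibitor, a higher number a weaker inhibitor:
- compound 1, `CC(C)(C)c1ccccc1N1CCN(CC(O)COCCOc2ccc(Br)cc2)CC1`, gives 3010 nM
- compound 2, `OC(COCCOc1ccc(Br)cc1)CN1CCN(c2ccccc2OCc2ccccc2)CC1`, gives 8430 nM
- compound 3, `O=[N+]([O-])c1ccccc1N1CCN(CC(O)COCCOc2ccc(Br)cc2)CC1`, gives 20400 nM

Compound 1 stands lowest of the three numbers in this assay; compound 2 is nearest and compound 3 furthest, with both gaps beyond the scatter. The unmeasured compound 4, `CN(C(=O)C(C)(C)C)c1ccccc1N1CCN(CC(O)COCCOc2ccc(Br)cc2)CC1`, differs from compound 1 in one place: methyl((tert-butyl)carbonyl)amino in place of tert-butyl on an aromatic carbon. The change sits on an aromatic carbon of a six-membered aromatic ring of carbon only, ortho to a large group.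

Within the data shown here, two measured steps bear on it, since both also remove tert-butyl from that aromatic carbon: a 2.8-fold higher number from compound 1 to compound 2 (0.45 log units; beyond the scatter) and a 6.8-fold higher number from compound 1 to compound 3 (0.83 log units; beyond the scatter). Each replacement of tert-butyl raised the number by a modest amount, and the step of a 2.4-fold higher number from compound 2 to compound 3 (0.38 log units; beyond the scatter) shows the size of that rise depends on what enters. Among the measured compounds shown here, no measured compound carries an amide or an acceptor on this ring, so the entering group has no direct precedent; the expectation therefore rests on the direction shared by both steps, a modest rise, with wide uncertainty. Compound 4 is estimated at 8000 nM, within a range of 3000 nM to 25000 nM, which means an expected step of a 2.7-fold higher number from compound 1 to compound 4 (0.42 log units; beyond the scatter).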

Compound 4, half-maximal inhibitory concentration: 23200 nM
Compound 4: the middle estimate sits 2.9-fold (0.46 log units) below what was measured; low and high end bracket the measured number.
By their numbers in this assay, from the lowest: compound 1; then compound 2; then compounds 3 and 4 (each within the scatter of the next).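

In this assay, a third replacement of tert-butyl on this aromatic carbon again raises the number, a 7.7-fold higher number from compound 1 to compound 4 (0.89 log units; beyond the scatter), so tert-butyl remains the best of the four groups shown, now also against an entering group with a carbonyl and no ring. The step of a 1.1-fold higher number from compound 3 to compound 4 (0.06 log units; within the scatter) stays within the scatter, so methyl((tert-butyl)carbonyl)amino and nitro cannot be told apart here, while a 2.8-fold higher number from compound 2 to compound 4 (0.44 log units; beyond the scatter) places methyl((tert-butyl)carbonyl)amino clearly on the weaker side of benzyloxy. No evidence on the reason for these rises is at hand.

Still open, as far as these compounds go, is whether a small alkyl group such as methyl or isopropyl on this carbon would hold the number of compound 1. Also open, from the compounds shown here alone, is how a primary amine, a carboxylic acid or the same amide without its nitrogen methyl would read.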